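The source may report more compounds than this note shows. Statements on the series, on what has been measured and on what is new or still open speak of the compounds shown alone.

Of the compounds shown here, two have so far been tested in a functional assay on A-375 cells (Homo sapiens) for antiproliferative activity, read by MTT assay, with a stated time of 24 h, tested at 0.02 ug/mL; on this read-out higher numbers stand for a stronger effect at the one concentration tested and lower numbers for a weaker effect. Compound 1, `Cc1c(C(=O)Nc2c(F)cc(-c3cccc(F)c3)cc2F)nc2ccc(F)cc2c1O`, gives -0.13% in this assay. Compound 2, `CCc1ccc2nc(C(=O)Nc3c(F)cc(-c4cccc(F)c4)cc3F)c(C)c(C(=O)O)c2c1`, gives -0.12% in this assay. On these two numbers compound 2 stands level with compound 1: the gap between them lies within the scatter of repeated measurements, so neither can be set apart from the other, and at the single concentration tested neither shows any inhibition of cell growth to speak of.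

Compound 3, `Cc1c(C(=O)Nc2c(F)cc(-c3cccc(F)c3)cc2F)nc2ccc(F)cc2c1C(=O)O`, has not yet been measured. Compared with compound 2 it differs in one place: fluoro in place of ethyl on an aromatic carbon. The remainder of the structure is unchanged.

Among the compounds with values here, no pair of measured compounds shows what this change does, so there is no measured step to lean on. Because compound 1 gives -0.13% and compound 2 gives -0.12% in this assay, both sitting at practically no effect, the expected step is one of no size beyond the scatter, namely a number 0.1 percentage points higher from compound 2 to compound 3 (within the scatter). Compound 3 is therefore estimated at 0% in this assay, with a range from -10% to 10%.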

Compound 3, a percentage reported as inhibition, at one concentration (the size of the read-out at that concentration, not a potency): -0.22%
For compound 3 the middle estimate is 0.2 percentage points above the measured one; low and high end bracket the measured number.
By their numbers in this assay, from the lowest: compounds 3, 1 and 2 (each within the scatter of the next).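

In this assay, fluoro in place of ethyl on this aromatic carbon of the shared core gives a number 0.1 percentage points lower from compound 2 to compound 3 (within the scatter) and so leaves the read-out where it was, even though the group that enters is smaller than the one that leaves. A second change, at another place on the same core, gives a number 0.1 percentage points lower from compound 1 to compound 3 (within the scatter) when carboxy stands in place of hydroxy on an aromatic carbon, so swapping these groups there also produces no difference that can be told apart. Neither change brings out any inhibition of cell growth at the one concentration tested, and no further data on hand bear on this result.

Still open, from the compounds shown here alone, is whether any other group on these two carbons can move the read-out at all, for instance an amine or a methoxy group in place of the fluoro, or a primary amide in place of the carboxy. Also open, going by these compounds, is whether compounds 1, 2 and 3 would stay level with one another at a higher concentration, where a real effect might appear and differences between these groups could be measured.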